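The source may report more compounds than this note shows. Statements on the series, on what has been measured and on what is new or still open speak of the compounds shown alone.

Of the compounds shown here, two built on a shared core have been measured in a functional assay on colon cells (Homo sapiens) for antiproliferative activity; a higher number here means a weaker inhibitor of growth, a lower number a stronger inhibitor of growth. Compound 1 `Cc1cn2c(/C=N/NC(=N)N)c(-c3ccncc3)nc2s1` gives 34700 nM. Compound 2 `Cc1sc2nc(-c3ccncc3)c(/C=N/NC(=N)N)n2c1C` gives 79400 nM. The two differ in a single place, and the step of a 2.3-fold higher number from compound 1 to compound 2 (0.36 log units; beyond the scatter) is modest. On these two numbers compound 1 stands at the lower end, which in this assay makes it the stronger growth inhibitor of the pair.

Compound 3 `Cc1cn2c(/C=N/NC(=N)N)c(-c3cccnc3)nc2s1` has not yet been measured. It differs from compound 1 in one place: pyridin-3-yl in place of pyridin-4-yl on an aromatic carbon. Among the compounds with values here, no measured step bears on this change; the only step recorded concerns a methyl group added elsewhere and says nothing about the pyridine. The direction of the step in this assay from compound 1 to compound 3 therefore cannot be read from what is known, and the expectation is for a number near that of compound 1, with a range wide enough to cover a modest move either way. Compound 3 is estimated at 35000 nM, between 12000 nM and 100000 nM. The expected step is a 1.0-fold higher number from compound 1 to compound 3 (0.00 log units; within the scatter).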

Compound 3, concentration for total growth inhibition: 20900 nM
The estimate for compound 3 lay 1.7-fold (0.22 log units) above the measured number; measured number inside the range.
By their numbers in this assay, from the lowest: compounds 3 and 1 (each within the scatter of the next); then compound 2.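

Replacing pyridin-4-yl with pyridin-3-yl on an aromatic carbon of the five-membered ring gives a 1.7-fold lower number from compound 1 to compound 3 (0.22 log units; within the scatter) in this assay and is the first step shown at this position. The nitrogen can therefore sit at either of these two places in the pyridine ring without a change that can be told apart from the scatter, and compound 1 and compound 3 read as equals in this assay. Nothing measured on these compounds bears on this result.

A phenyl ring, which has carbon where these pyridines have their ring nitrogen, would test whether that nitrogen matters at this position at all, and pyridin-2-yl would complete the set of attachment points. Also open, going by these compounds, is whether the added methyl behind a 2.3-fold higher number from compound 1 to compound 2 (0.36 log units; beyond the scatter) would have a similar effect alongside pyridin-3-yl, or whether the two changes depend on each other.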